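Benzothiazol swap on the piperazine-linked series

A few compounds are considered here, and "the series" means these few. Any claim that something is new, unique, unknown or untested is made for them only; others in the source may bear on it.

compound 1 `Cc1ccc(-c2nnc(SCCCN3CCN(c4nc5ccccc5o4)CC3)o2)cc1`: 133000 nM
compound 2 `Clc1ccc(-c2nnc(SCCCN3CCN(c4nc5ccccc5o4)CC3)o2)cc1`: 101000 nM
compound 3 `c1ccc(-c2nnc(SCCCN3CCN(c4nc5ccccc5o4)CC3)o2)cc1`: 67000 nM

All three values come from a functional assay on HeLa cells (Homo sapiens) for inhibition, read by MTT assay, with a stated time of 72 h (a higher number here means a weaker inhibitor, a lower number a stronger inhibitor), and differ only in the group on an aromatic carbon. In this assay compound 2 gives 101000 nM and stands within the scatter of the other two compounds. The steps that touch it are a 1.3-fold lower number from compound 1 to compound 2 (0.12 log units; within the scatter) and a 1.5-fold lower number from compound 2 to compound 3 (0.18 log units; within the scatter).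

The next change is to compound 4 `Clc1ccc(-c2nnc(SCCCN3CCN(c4nc5ccccc5s4)CC3)o2)cc1`, and it lies elsewhere in the structure: 1,3-benzothiazol-2-yl in place of 1,3-benzoxazol-2-yl on an amine nitrogen in a ring. One oxygen leaves and one sulfur enters, on the group carried by an amine nitrogen in a ring.

Within the data shown here, no measured step changes this group, so the data offer no direct measure of the swap. The three measured steps bear on it only indirectly, as a guide to how far values have moved in this small set. Even a 2.0-fold lower number from compound 1 to compound 3 (0.30 log units; within the scatter) stays within the scatter. On that limited basis, no step beyond the scatter is expected in this assay, and no direction is favoured. The estimated change is a 1.1-fold lower number from compound 2 to compound 4 (0.05 log units; within the scatter), with wide uncertainty. The expected value for compound 4 is 90000 nM, within an estimated range of 40000 nM to 200000 nM.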

Compound 4, half-maximal inhibitory concentration: 177000 nM
Beside the measured number, compound 4's estimate is 2.0-fold (0.29 log units) below it; the range from low to high includes it.
By their numbers in this assay, from the lowest: compounds 3, 2, 1 and 4 (each within the scatter of the next, the first and the last beyond it).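

Among these compounds, the step at this position is the first in the set that touches the group on an amine nitrogen in a ring, as the earlier steps all changed only the group on an aromatic carbon. In this assay, a 1.8-fold higher number from compound 2 to compound 4 (0.24 log units; within the scatter) leaves compound 2 and compound 4 indistinguishable, so this single exchange of oxygen for sulfur, with the chloro group held constant, gives no measurable separation and establishes no preference between 1,3-benzoxazol-2-yl and 1,3-benzothiazol-2-yl. No accompanying measurement bears on this pair or offers any account of the result.

Still open, from the compounds shown here alone, is whether the same exchange would also stay within the scatter on the methyl-bearing compound 1 or the unsubstituted compound 3, since the present reading rests on the chloro pair alone. Also open, going by these compounds, is whether a plain phenyl group or a simple amine on the ring nitrogen in place of these fused groups, or a longer chain in the linker, would produce a step beyond the scatter in this assay at all.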